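The source may report more compounds than this note shows. Statements on the series, on what has been measured and on what is new or still open speak of the compounds shown alone.

Compound 1 `Cc1c(C)c(S(=O)(=O)N2CCC(N3CCC(C)CC3)CC2)c(C)c2c1OC(C)(C)C2`, compound 2 `CC1CCN(C2CCN(S(=O)(=O)c3cnc(Cl)s3)CC2)CC1` and compound 3 `CC1CCN(C2CCN(S(=O)(=O)c3sc(Cl)nc3C3CC3)CC2)CC1` keep the shared core and differ only in the group carried on the sulfonyl sulfur. In an ADME assay on HCT-116 cells (Homo sapiens) for cytotoxicity, read by CellTiter-Glo, with a stated time of 72 h (on this read-out higher numbers stand for weaker inhibition and lower numbers for stronger inhibition), compound 1 gives > 10000 nM, a limit of the assay rather than a number. Compound 2 in this assay gives > 10000 nM, again a limit. Compound 3 in this assay gives > 10000 nM, also a limit. Among the compounds with values here, the single one-place change measured so far, a step that the two limits leave unreadable from compound 2 to compound 3, can therefore not be read for size or direction. Compound 2 stands at the limit of > 10000 nM in this assay, at which 3 of the 3 values shown sit; as every value shown is a limit, no order among the three can be read.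

Compound 4 `CC1CCN(C2CCN(S(=O)(=O)c3cc(Cl)cc(Cl)c3)CC2)CC1` is the next member and differs from compound 2 in one place: 3,5-dichlorophenyl in place of 2-chloro-1,3-thiazol-5-yl on a sulfonyl sulfur. Within the data shown here, no measured step bears directly on this exchange, and the only step available is unreadable. With three limits and no readable step, there is no basis to expect compound 4 to move into measurable range; the expectation is that it sits at the limit as well, with the step that the limit leaves unreadable from compound 2 to compound 4 expected to stay within the usual scatter. Compound 4 is accordingly estimated at 15000 nM, within a range from 5000 nM to 50000 nM.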

Compound 4, half-maximal inhibitory concentration: > 5000 nM
Compound 4: only a limit was reported; the forecaster's own chance of this, stated with the estimate: 85%; the middle value is on the limit's open side.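

In this assay compound 4 gives > 5000 nM, a limit and not a number. Compound 2 and compound 4 both stand at limits, and the step between them cannot be read for size or direction. The compounds shown leave open whether any group on the sulfonyl sulfur gives a measurable value in this assay.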